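Triazole substituent swap on the chalcone series

The compounds below may be only part of what the source reports. "The series", "measured", "known", "first", "only" and "open" are said of these compounds alone.

For the measured compounds named here, compound 2 `COc1ccccc1N1CCN(CC(=O)Nc2ccc(C(=O)/C=C/c3cn(Cc4ccc(Br)cc4)nn3)cc2)CC1` gives 34000 nM in a functional assay on A549 cells (Homo sapiens) for inhibition, read by MTT assay (on this read-out higher numbers stand for weaker inhibition and lower numbers for stronger inhibition), the highest of the two numbers recorded so far; compound 1 `O=C(CN1CCN(c2ccccc2F)CC1)Nc1ccc(C(=O)/C=C/c2cn(Cc3ccc(Br)cc3)nn2)cc1` gives 14700 nM, and the step of a 2.3-fold higher number from compound 1 to compound 2 (0.36 log units; beyond the scatter) is the only measured change in the set. Compound 3 `CCCCCCCCCCn1cc(/C=C/C(=O)c2ccc(NC(=O)CN3CCN(c4ccccc4OC)CC3)cc2)nn1` has not been measured. It differs from compound 2 by nonyl in place of 4-bromophenyl on a saturated chain carbon bound to an aromatic nitrogen; cut one bond further out, the same difference reads 4-bromobenzyl to decyl. Going by the values given here, no measured step touches this position: the single step recorded, between compound 1 and compound 2, concerns the substituent on the aryl ring of the piperazine and says nothing about the group on the triazole nitrogen. Among the compounds with values here, the expectation for compound 3 therefore rests on no comparable precedent, and the expected step of a 1.1-fold lower number from compound 2 to compound 3 (0.05 log units; within the scatter) is set close to none beyond the scatter, with a wide range in either direction. For compound 3 the estimated value is 30000 nM, expected to lie between 8000 nM and 120000 nM.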

Compound 3, half-maximal inhibitory concentration: 62500 nM
Compound 3: the middle estimate sits 2.1-fold (0.32 log units) below what was measured; low and high end bracket the measured number.
By their numbers in this assay, from the lowest: compound 1; then compounds 2 and 3 (each within the scatter of the next).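

In this assay, the place on a saturated chain carbon bound to an aromatic nitrogen now has its first reading: nonyl in place of 4-bromophenyl gives a 1.8-fold higher number from compound 2 to compound 3 (0.26 log units; within the scatter) and so stays inside the usual scatter. In this pair, the 4-bromobenzyl to decyl exchange removes the aromatic ring and the bromine without a change that can be told from repeat variation, so that ring is not required for a reading at this level. Nothing measured bears on why the two compounds read alike.

Open, going by these compounds, is how a shorter chain such as butyl, or an amine carried on the decyl chain, reads at this place. Also open, on these data alone, is whether the fluoro and methoxy difference between compound 1 and compound 2 carries over when decyl replaces 4-bromobenzyl.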